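A Chloro Group Lost From Compound 2

A few compounds are considered here, and "the series" means these few. Any claim that something is new, unique, unknown or untested is made for them only; others in the source may bear on it.

Values in a functional assay on A549 cells (Homo sapiens) for antiproliferative activity, read by MTT assay, with a stated time of 72 h; a lower number here means a stronger inhibitor, a higher number a weaker inhibitor:
Compound 1 `COc1cc(CCc2ccncc2)cc(OC)c1O`: > 25000 nM, a limit of the assay
Compound 2 `COc1cc(CCc2ccc(Cl)c(Cl)c2)cc(OC)c1O`: 13400 nM
Compound 3 `COc1ccc(CCc2ccccc2Cl)cc1OC`: > 25000 nM, a limit of the assay

Among these three compounds, only compound 2 has a measured number in this assay, at 13400 nM. The other two results are not numbers, and they cannot be ranked against each other. This is the limit of > 25000 nM in this assay, at which 2 of the 3 values shown sit.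

The next compound to be tested is compound 4 `COc1cc(CCc2ccc(Cl)cc2)cc(OC)c1O`, which comes from compound 2 through a single structural change: hydrogen in place of chloro on an aromatic carbon. In words, it carries hydrogen in place of chloro on an aromatic carbon. Within the data shown here, no pair of measured compounds shows what this exchange does, so the expectation rests on little. Compound 2 gives 13400 nM, a measured number. That leaves little room for a weaker result to appear as a number before the limit of the assay is reached. A modest loss of potency is expected, of a size near the scatter, and compound 4 may well reach the limit and give no number at all. The expected change is a 1.5-fold higher number from compound 2 to compound 4 (0.17 log units; within the scatter). For compound 4 the estimated value is 20000 nM. The expected range for compound 4 runs from 10000 nM to 40000 nM.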

Compound 4, half-maximal inhibitory concentration: 22900 nM
The estimate for compound 4 lay 1.1-fold (0.06 log units) below the measured number; low and high end bracket the measured number.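

The exchange of hydrogen for chloro, at the place ortho to a chloro group and meta to a large group, can now be read directly in this assay: it gives a 1.7-fold higher number from compound 2 to compound 4 (0.23 log units; within the scatter). The earlier compounds shown here offered no pair for this exchange, and this first pair shows that, with the other chloro group kept, the two compounds cannot be told apart in this assay, so this position shows no clear need for chloro. Compound 4 still gives a number rather than a limit, so the step can be read, but both compounds stand in a weak part of the range, where little room remains before numbers give way to limits: the limit of > 25000 nM in this assay, at which 2 of the 4 values shown sit.

The compounds shown do not tell what the shared core would give with hydrogen in place of the remaining chloro group as well, or whether that group alone carries the measurable activity of this pair. They also leave open what a methoxy group, an amine or a carboxylic acid would give at the position studied here, and whether any such group would move the result clearly beyond the scatter.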